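Rearranging an Amino Side Chain on a Shared Core

This account rests on a few compounds, and the source may have more. Where it says the series, first, only, none or still open, it means among the compounds named here.

In a physicochemical assay for solubility, read by nephelometry, measured as kinetic solubility, with a stated time of 30 min (a higher number here means a more soluble compound, a lower number a less soluble compound), compound 3 `CC(C)(CN)Oc1ccc([C@H]2CC[C@]3(CC2)OOC2(O3)C3CC4CC(C3)CC2C4)cc1` gives > 100 ug/mL, which is a limit of the assay and not a number. Compound 1 `NCCOc1ccc([C@H]2CC[C@]3(CC2)OOC2(O3)C3CC4CC(C3)CC2C4)cc1` gives > 100 ug/mL, also a limit. Compound 2 `CS(=O)(=O)N1CCN(CCCOc2ccc([C@H]3CC[C@]4(CC3)OOC3(O4)C4CC5CC(C4)CC3C5)cc2)CC1` gives < 1.6 ug/mL, which is a limit as well.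

Compound 4 `NCCCCOc1ccc([C@H]2CC[C@]3(CC2)OOC2(O3)C3CC4CC(C3)CC2C4)cc1` has the same atoms as compound 3, joined differently. It carries 4-aminobutyl in place of 1-(aminomethyl)-1-methylethyl on an oxygen on an aromatic ring.

Among the measured compounds shown here, two measured steps bear on this change. The closer guide is a step that the two limits leave unreadable from compound 1 to compound 3, which also exchanges one amino-bearing chain for another on that oxygen. It shows no drop that can be read, but it cannot give a size. The second guide is an at least 62-fold lower number from compound 1 to compound 2 (1.79 log units; beyond the scatter), where (4-(methylsulfonyl)piperazin-1-yl)methyl takes the place of amino. That large step involved losing the amino group, whereas compound 4 keeps it, so a drop of that kind is not expected here.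

In this assay the expected outcome is an at least 1.1-fold lower number from compound 3 to compound 4 (0.04 log units; that floor lies within the scatter), with no fall beyond the scatter anticipated. For compound 4 the estimated solubility is 90 ug/mL, with an expected range from 35 ug/mL to 100 ug/mL.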

Compound 4, solubility: 50 ug/mL
Compound 4: middle estimate off by 1.8-fold (0.26 log units), on the high side, and the stated range covers the measured number.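

In this assay, compound 4 is the only amino-chain compound shown that gives a number and not a limit, so an amino chain on this oxygen on an aromatic ring now has a readable value. Set against the two shorter-named amino chains, the readings are an at least 2.0-fold lower number from compound 3 to compound 4 (0.30 log units; that floor lies within the scatter) and an at least 2.0-fold lower number from compound 1 to compound 4 (0.30 log units; that floor lies within the scatter), and both are only floors because compound 1 and compound 3 sit at a limit: the limit of > 100 ug/mL in this assay, at which 2 of the 4 values shown sit. The gap to the 4-(methylsulfonyl)piperazin-1-yl side chain stays wide whichever way the amino chain is arranged, with an at least 31-fold higher number from compound 2 to compound 4 (1.49 log units; beyond the scatter).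

Going by these compounds, the step between compound 1 and compound 3 cannot be read, so the order of 2-aminoethyl and 1-(aminomethyl)-1-methylethyl stays open, as does whether either truly differs from 4-aminobutyl by more than the scatter. Also open, on these data alone, is how an aminohexyl chain, or a chain ending in a carboxylic acid, would read on the same oxygen on the shared core.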